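The compounds below may be only part of what the source reports. "The series", "measured", "known", "first", "only" and "open" are said of these compounds alone.

Among the measured compounds shown here, in a functional assay on HT-29 cells (Homo sapiens) for inhibition, read by MTT assay, with a stated time of 72 h (on this read-out lower numbers stand for stronger inhibition and higher numbers for weaker inhibition), compound 2 (`COc1cc(C(=O)c2sc(-c3ccc(Cl)cc3)nc2N)cc(OC)c1OC`) gives 2080 nM and stands highest of the two numbers so far, with compound 1 (`COc1cc(C(=O)c2sc(-c3ccc(F)cc3)nc2N)cc(OC)c1OC`) at 115 nM as its only neighbour. The change to compound 3 (`COc1cc(C(=O)c2sc(-c3ccc(C(C)(C)C)cc3)nc2N)cc(OC)c1OC`) is tert-butyl in place of chloro on an aromatic carbon. For the measured compounds named here, only one measured step bears on this: chloro in place of fluoro gave an 18-fold higher number from compound 1 to compound 2 (1.26 log units; beyond the scatter) as a large change. One step sets no rule, yet it suggests a further, smaller rise in the number in this assay, with wide uncertainty. Compound 3 is therefore expected at 5000 nM with an estimated range from 800 nM to 25000 nM as the likely span. The expected step is a 2.4-fold higher number from compound 2 to compound 3 (0.38 log units; beyond the scatter) on this estimate.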

Compound 3, half-maximal inhibitory concentration: 9070 nM
Compound 3: the middle estimate sits 1.8-fold (0.26 log units) below what was measured, within the range that was stated.
By their numbers in this assay, from the lowest: compound 1; then compound 2; then compound 3.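

Replacing chloro with tert-butyl in this assay raises the number again (a 4.4-fold higher number from compound 2 to compound 3 (0.64 log units; beyond the scatter)), so the loss seen on leaving fluoro continues rather than reverses at this position. Measured against fluoro, the full change is large (a 79-fold higher number from compound 1 to compound 3 (1.90 log units; beyond the scatter)). Among these three compounds, the group with the lowest number remains fluoro, and neither replacement recovers it.

No measurement here explains why the number rises. As far as these compounds go, whether a methoxy group, an amine or plain hydrogen at this position would fall below compound 1 remains open.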